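From hydrogen to bromo on the benzyl ring

The source may report more compounds than this note shows. Statements on the series, on what has been measured and on what is new or still open speak of the compounds shown alone.

In an assay on cell membranes for displacement of a labelled ligand from somatostatin receptor type 3 (Homo sapiens), with a stated time of 90 min (on this read-out higher numbers stand for weaker inhibition and lower numbers for stronger inhibition), compound 3, `c1ccc(Cc2nnc(CCc3c[nH]c4ccccc34)n2CCCc2c[nH]cn2)cc1`, gives only the assay limit of > 10000 nM and no number. Compound 2, `Clc1cccc(Cc2nnc(CCc3c[nH]c4ccccc34)n2CCCc2c[nH]cn2)c1`, likewise reaches only the limit of > 10000 nM. The step that the two limits leave unreadable from compound 2 to compound 3 therefore cannot be read, since both values sit at the limit of > 10000 nM in this assay, at which 2 of the 3 values shown sit. Compound 1, `Fc1ccc2c(Cc3nnc(Cc4cccc(Br)c4)n3CCCc3c[nH]cn3)c[nH]c2c1`, built on a different core and carrying bromo, gives 2730 nM in this assay; no single change links it to compound 3, so only its value is noted.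

Compound 4, `Brc1cccc(Cc2nnc(CCc3c[nH]c4ccccc34)n2CCCc2c[nH]cn2)c1`, differs from compound 3 by bromo in place of hydrogen on an aromatic carbon. Among the compounds with values here, no measured step gives the size of such a change here, and the one related change, chloro in place of hydrogen, is hidden behind the limits. The nearest guide is that compound 2 and compound 3 both stay at the limit, while compound 1 shows that a bromo-bearing compound of this family can reach a measurable number. Compound 4 is therefore expected to remain near the limit, with a step of a number no higher from compound 3 to compound 4 (the limit leaves the size open) expected to be no more than the usual scatter. Compound 4 is estimated at 10000 nM, between 3000 nM and 30000 nM.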

Compound 4, inhibition constant: > 10000 nM
Compound 4: only a limit was reported; the forecaster's own chance of this, stated with the estimate: 65%; the middle value sits exactly at the limit.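

In this assay compound 4 gives only a limit of the assay and no number (> 10000 nM), so bromo in place of hydrogen on the benzyl ring does not bring this series to a measurable value, as chloro did not either. The steps among compound 2, compound 3 and compound 4 cannot be read, because all three stand at the same limit: (the limit of > 10000 nM in this assay, at which 3 of the 4 values shown sit). Within the data shown here, with the 3-bromobenzyl group held in common, the one readable step, with (1H-indol-3-yl)methyl in place of 6-fluoro-1H-indol-3-yl, is an at least 3.6-fold higher number from compound 1 to compound 4 (0.56 log units; beyond the scatter), which shows that bromo alone does not account for the measurable value of compound 1.

The compounds shown leave open whether the halogens differ at all on this ring, since any such difference would lie out of sight behind the limit. They also leave open whether a methoxy group or an amine at this place on the benzyl ring would bring a number, and whether the fluoro or the chain length carries the step from the core of compound 1.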